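The compounds below may be only part of what the source reports. "The series", "measured", "known", "first", "only" and "open" are said of these compounds alone.

Going by the values given here, in a functional assay for antagonist activity at thyroid hormone receptor beta (Homo sapiens), read by fluorescence polarization, with a stated time of 3 h (a lower number here means a stronger inhibitor, a higher number a weaker inhibitor), compound 2, with the structure `CN(Cc1cccc(F)c1)C(=O)c1sc(-c2ccc(S(C)(=O)=O)c([N+](=O)[O-])c2)nc1C(F)(F)F`, gives 2800 nM, the lowest of the three numbers measured so far. Compound 1, with the structure `CN(Cc1cccc(F)c1)C(=O)c1cnc(-c2ccc(S(C)(=O)=O)c([N+](=O)[O-])c2)s1`, gives 8500 nM in this assay, and the step of a 3.0-fold lower number from compound 1 to compound 2 (0.48 log units; beyond the scatter) lies beyond the scatter. Compound 3, with the structure `CC1Cc2ccccc2N1C(=O)c1sc(-c2ccc(S(C)(=O)=O)c([N+](=O)[O-])c2)nc1C(F)(F)F`, gives 5200 nM in this assay, and the step of a 1.9-fold higher number from compound 2 to compound 3 (0.27 log units; within the scatter) stays within the scatter.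

Compound 4, with the structure `CC1CCN(C(=O)c2sc(-c3ccc(S(C)(=O)=O)c([N+](=O)[O-])c3)nc2C(F)(F)F)CC1`, has not yet been measured. It differs from compound 2 in one place: 4-methylpiperidin-1-yl in place of (3-fluorobenzyl)(methyl)amino on a carbonyl carbon. Among the compounds with values here, the only measured step that bears on this change is the one from compound 2 to compound 3, where the group on the same carbonyl carbon was also exchanged, and that step stayed within the scatter. On that basis the step of a 1.4-fold higher number from compound 2 to compound 4 (0.15 log units; within the scatter) is expected to stay within the scatter as well, with no clear direction. For compound 4 the estimate in this assay is therefore 4000 nM, with a likely range from 1500 nM to 11000 nM.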

Compound 4, half-maximal inhibitory concentration: 310 nM
The estimate for compound 4 lay 13-fold (1.11 log units) above the measured number, outside the stated range (below it).
By their numbers in this assay, from the lowest: compound 4; then compounds 2, 3 and 1 (each within the scatter of the next, the first and the last beyond it).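

Going by these compounds alone, the group on the carbonyl carbon matters much more than the earlier compounds suggested: in this assay, 4-methylpiperidin-1-yl gives a 9.0-fold lower number from compound 2 to compound 4 (0.96 log units; beyond the scatter), and it gives a 17-fold lower number from compound 3 to compound 4 (1.22 log units; beyond the scatter), although the earlier exchange at this place stayed within the scatter. The entering group has fewer heavy atoms than (3-fluorobenzyl)(methyl)amino and lacks its six-membered aromatic ring of carbon only, but this single change cannot show which of these differences counts, if either does. Nothing measured here explains the gain in potency.

Left open is whether the methyl group itself contributes, a question that plain piperidin-1-yl or morpholin-4-yl on the same carbonyl carbon could answer. Also open, from the compounds shown here alone, is whether the gain holds on the core of compound 1, which has hydrogen in place of trifluoromethyl.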